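The source may report more compounds than this note shows. Statements on the series, on what has been measured and on what is new or still open speak of the compounds shown alone.

Among the measured compounds shown here, in an assay on membranes from HeLa cells for displacement of a labelled ligand from adenosine receptor A3 (Homo sapiens), read by scintillation counting, with a stated time of 180 min, tested at 1 uM (on this read-out lower numbers stand for less inhibition and higher numbers for more inhibition at the one concentration tested (going by the name of the read-out)), compound 1 `CCCOC(=O)C1=C(C)NC(=O)NC1c1cccs1` gives 32% and compound 2 `CC1=C(C(=O)OC(C)(C)C)C(c2cccs2)NC(=O)N1` gives 7%; the only measured step between compounds that differ in one place, tert-butyl in place of propyl on an oxygen next to a carbonyl group, is a number 25 percentage points lower from compound 1 to compound 2 (beyond the scatter). Compound 3 `CC1=C(C(=O)C2CC2)C(c2ccoc2)NC(=O)N1` gives 16% in this assay, the second highest of the three numbers: compound 2 lies within the scatter of it, while compound 1 lies beyond the scatter above it.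

Compound 4 `CC1=C(C(=O)C2CC2)C(c2cccs2)NC(=O)N1` differs from compound 3 by thiophen-2-yl in place of furan-3-yl on a saturated ring carbon. For the measured compounds named here, no measured step covers this change: the one step known alters the ester alkyl and not the aryl group, and both compound 1 and compound 2 already carry thiophen-2-yl, so no comparison isolates the aryl. With nothing bearing on it, no step beyond the scatter is expected in this assay in either direction. Compound 4 is therefore estimated at 20% in this assay, with a range from 4% to 40%, which amounts to an expected step of a number 4 percentage points higher from compound 3 to compound 4 (within the scatter).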

Compound 4, a percentage reported as inhibition, at one concentration (the size of the read-out at that concentration, not a potency): 15%
The estimate for compound 4 lay 5 percentage points above the measured number, and the stated range covers the measured number.
By their numbers in this assay, from the lowest: compounds 2, 4 and 3 (each within the scatter of the next); then compound 1.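

In this assay, the group on the saturated ring carbon can now be read on its own: thiophen-2-yl in place of furan-3-yl gives a number 1 percentage points lower from compound 3 to compound 4 (within the scatter), so this exchange does not register with cyclopropylcarbonyl on the core. With thiophen-2-yl held fixed, the group on the carbonyl carbon can also be compared: cyclopropyl in place of tert-butoxy gives a number 8 percentage points higher from compound 2 to compound 4 (within the scatter) and cyclopropyl in place of propoxy gives a number 17 percentage points lower from compound 1 to compound 4 (beyond the scatter), so among these three groups only propoxy stands apart. Nothing available explains either outcome.

From the compounds shown here alone, it remains open whether the exchange of thiophen-2-yl and furan-3-yl would also leave the number unmoved with propoxy on the carbonyl carbon. Also open, going by these compounds, is how a phenyl or pyridine ring on the saturated ring carbon, or an amine or longer chain on the carbonyl carbon, would read.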